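The source may hold more compounds than are shown below. What is called first, only, known or untested is meant among the compounds shown, and "the series" means these compounds.

Compound 1 `CCCC1=C(C(=O)OCC)C(c2ccco2)NC(=O)N1` gives 256 nM in an assay on HEK293 cells for displacement of a labelled ligand from adenosine receptor A2b (Homo sapiens), with a stated time of 30 min; on this read-out lower numbers stand for stronger inhibition and higher numbers for weaker inhibition.
Compound 2 `CCOC(=O)C1=C(C)N(C)C(=O)NC1c1ccco1` gives 6540 nM in this assay.
Compound 3 `CCOC(=O)C1=C(C)N(C)C(=O)NC1c1ccoc1` gives 4260 nM in this assay.

Among these three numbers compound 3 stands second highest. Its nearest neighbour is compound 2, whose number is higher by an amount that lies within the usual scatter, so the two cannot be told apart. Compound 1, which carries a different pattern of groups on the shared core, gives a far lower number, and that gap is well beyond the scatter.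

Compound 4 `CCOC(=O)C1=C(C)N(C)C(=O)NC1c1ccsc1` is the next compound. It differs from compound 3 in one place: thiophen-3-yl in place of furan-3-yl on a saturated ring carbon. Going by the values given here, the only measured step that touches the same position is the one from compound 2 to compound 3, which moved the attachment point of the furan ring and gave a 1.5-fold lower number from compound 2 to compound 3 (0.19 log units; within the scatter). Among the compounds with values here, no measured pair replaces the oxygen of this five-membered ring by sulfur, so the size of the present change is not covered by the data. With only a within-scatter precedent at this position, no step beyond the scatter is expected in this assay.

Compound 4 is therefore estimated at 3500 nM, with a range from 1200 nM to 10000 nM, which means an expected step of a 1.2-fold lower number from compound 3 to compound 4 (0.09 log units; within the scatter).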

Compound 4, inhibition constant: 2970 nM
Estimate against measurement, compound 4: 1.2-fold (0.07 log units) above, and the stated range covers the measured number.
By their numbers in this assay, from the lowest: compound 1; then compounds 4, 3 and 2 (each within the scatter of the next, the first and the last beyond it).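

Thiophen-3-yl in place of furan-3-yl on the saturated ring carbon is the first measured swap of the ring oxygen for sulfur at this position, and in this assay it gives a 1.4-fold lower number from compound 3 to compound 4 (0.16 log units; within the scatter), so these two rings cannot be told apart here. Going by these compounds alone, the comparison with the furan-2-yl ring gives a 2.2-fold lower number from compound 2 to compound 4 (0.34 log units; beyond the scatter), the first step at this position to clear the scatter, though only modestly, and it combines a change of ring atom with a change of attachment point, so neither can be credited alone. No measurement shown here offers an explanation for how close these numbers lie.

From the compounds shown here alone, all the groups compared at this position are five-membered aromatic rings with one hetero atom, so it remains open whether a phenyl ring, a pyridine ring or an open chain such as butyl would keep the number in this range. Going by these compounds, compound 1, at 256 nM, differs from compound 2 in more than one place, so how much each difference contributes to the gap between them also remains open.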